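This account rests on a few compounds, and the source may have more. Where it says the series, first, only, none or still open, it means among the compounds named here.

Measured in a functional assay on HCT-116 cells (Homo sapiens) for inhibition, read by MTT assay, with a stated time of 72 h; a lower number here means a stronger inhibitor, a higher number a weaker inhibitor:

- compound 1 `Nc1ccccc1NC(=O)c1ccc(CNC(=O)/C=C/c2cnc3ccccn23)cc1`: 2300 nM
- compound 2 `Nc1ccc(F)cc1NC(=O)c1ccc(CNC(=O)/C=C/c2cnc3cccnn23)cc1`: 4290 nM
- compound 3 `Cc1nc2ccccn2c1/C=C/C(=O)NCc1ccc(C(=O)Nc2ccccc2N)cc1`: 1430 nM

Compound 2, at 4290 nM, lies within the scatter of compound 1, at 2300 nM. Its number is higher than that of compound 3, at 1430 nM, and this gap is beyond the scatter.

Compound 4 `Nc1cc(F)ccc1NC(=O)c1ccc(CNC(=O)/C=C/c2cnc3cccnn23)cc1` has not yet been measured. It has the same atoms as compound 2, joined differently: 2-amino-4-fluorophenyl in place of 2-amino-5-fluorophenyl on an amide-type nitrogen. In words, 2-amino-4-fluorophenyl stands in place of 2-amino-5-fluorophenyl on an amide-type nitrogen.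

Within the data shown here, none of the three measured compounds shows what this exchange does, since no measured pair differs in it. Among the measured compounds shown here, the only measured step is a different change, methyl in place of hydrogen on an aromatic carbon, and it gives a 1.6-fold lower number from compound 1 to compound 3 (0.21 log units; within the scatter). That step stays within the scatter, but it offers only weak guidance here. With nothing pointing in either direction, no step beyond the scatter is expected in this assay.

The estimated outcome is a 1.3-fold lower number from compound 2 to compound 4 (0.13 log units; within the scatter), a change not expected to exceed the scatter. Compound 4 is therefore expected at 3200 nM, with an estimated range from 1200 nM to 8000 nM.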

Compound 4, half-maximal inhibitory concentration: 2260 nM
Compound 4: the middle estimate sits 1.4-fold (0.15 log units) above what was measured; the measured number falls inside the stated range.
By their numbers in this assay, from the lowest: compounds 3, 4, 1 and 2 (each within the scatter of the next, the first and the last beyond it).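

In this assay, among these compounds, placing 2-amino-4-fluorophenyl in place of 2-amino-5-fluorophenyl on the amide-type nitrogen gives a 1.9-fold lower number from compound 2 to compound 4 (0.28 log units; within the scatter), the first reading of this exchange, and the step stays within the scatter. The two groups hold the same heavy atoms and differ only in how these are joined, so for this one pair on this one core, the assay does not separate the two fluorine placements. Nothing available accounts for the size or direction of this small step, and the result rests on the two numbers alone.

The compounds shown leave open whether plain 2-aminophenyl, the group carried by compound 1 and compound 3, would stand apart from either fluorinated group if it sat on the core of compound 2 and compound 4. They also leave open what a different group on the same amide-type nitrogen, such as 2-hydroxyphenyl or 2-amino-5-chlorophenyl, would do in this assay, and whether the same exchange would read alike on the core of compound 1.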